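A carbamate series and an unmeasured analogue

This account rests on a few compounds, and the source may have more. Where it says the series, first, only, none or still open, it means among the compounds named here.

Three compounds sharing one core were tested in an ADME assay on a cell-free system (plasma, Homo sapiens), read by HPLC, with a stated time of 120 min, at 37 degrees C; on this read-out lower numbers stand for a less stable compound and higher numbers for a more stable compound. Compound 1 `CC(C)COC(=O)N1CCN(C(=O)c2nc(Nc3cc(C4CC4)[nH]n3)c3cc(Cl)ccc3n2)C[C@H]1C` gives 73.7%, compound 2 `CCCCCOC(=O)N1CCN(C(=O)c2nc(Nc3cc(C4CC4)[nH]n3)c3cc(Cl)ccc3n2)C[C@H]1C` gives 74.4%, and compound 3 `CC(OC(=O)C(C)C)OC(=O)N1CCN(C(=O)c2nc(Nc3cc(C4CC4)[nH]n3)c3cc(Cl)ccc3n2)C[C@H]1C` gives 17.4%. Compound 3 stands lowest of the three, with the nearest value being that of compound 1 and the furthest that of compound 2. The step of a number 0.7 percentage points higher from compound 1 to compound 2 (within the scatter) lies within the scatter, whereas a number 56.3 percentage points lower from compound 1 to compound 3 (beyond the scatter) and a number 57 percentage points lower from compound 2 to compound 3 (beyond the scatter) are both large drops.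

Compound 4 `C[C@@H]1CN(C(=O)c2nc(Nc3cc(C4CC4)[nH]n3)c3cc(Cl)ccc3n2)CCN1C(=O)OCOC(=O)C(C)(C)C` differs from compound 3 by (((tert-butyl)carbonyl)oxy)methyl in place of 1-((isopropylcarbonyl)oxy)ethyl on an oxygen next to a carbonyl group. Going by the values given here, no measured step bears directly on this change: the two large steps only show that the group present in compound 3 is paired with a much lower number than the plain chains in compound 1 and compound 2, and compound 4 keeps a group of the same kind, with the same atoms joined differently. The expectation in this assay is therefore a number near that of compound 3, possibly somewhat higher but well short of compound 1, estimated as a number 12.6 percentage points higher from compound 3 to compound 4 (beyond the scatter). Compound 4 is expected to give 30%, within a range from 10% to 60%.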

Compound 4, percent of the compound remaining: 0%
Estimate against measurement, compound 4: 30 percentage points above, and the stated range ends above it.
By their numbers in this assay, from the lowest: compound 4; then compound 3; then compounds 1 and 2 (each within the scatter of the next).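

In this assay the atoms alone do not set the number: the groups in compound 3 and compound 4 have the same atoms joined differently on an oxygen next to a carbonyl group, yet the read-out moves beyond the scatter (a number 17.4 percentage points lower from compound 3 to compound 4 (beyond the scatter)), so the earlier picture of one low-reading kind of group needs refining. Against the plain chains the drops are larger, a number 73.7 percentage points lower from compound 1 to compound 4 (beyond the scatter) and a number 74.4 percentage points lower from compound 2 to compound 4 (beyond the scatter), and these leave compound 4 lowest of the four, so (((tert-butyl)carbonyl)oxy)methyl is paired with a lower number here than 1-((isopropylcarbonyl)oxy)ethyl, and both with much lower numbers than isobutyl or pentyl. Nothing measured here explains why the two arrangements of the same atoms part in this way.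

The change from compound 3 to compound 4 alters both ends of the group at once, the carbon bound to the oxygen and the far end of the ester, so the effect of each end remains unseparated. Hybrids such as ((isopropylcarbonyl)oxy)methyl or 1-(((tert-butyl)carbonyl)oxy)ethyl would be the groups that could tell those two ends apart.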